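Replacing the aryl group with a decyl chain on the triazole

The source may report more compounds than this note shows. Statements on the series, on what has been measured and on what is new or still open speak of the compounds shown alone.

Compound 1 `O=C1O[C@H]([C@@H](O)Cn2cc(-c3ccc(Br)cc3)nn2)C(OCc2ccccc2)=C1OCc1ccccc1`: 3760 nM
Compound 2 `CCCCCc1ccc(-c2cn(C[C@H](O)[C@H]3OC(=O)C(OCc4ccccc4)=C3OCc3ccccc3)nn2)cc1`: 12200 nM

Both compounds were tested in a functional assay on SW-620 cells (Homo sapiens) for antiproliferative activity, read by MTT assay, with a stated time of 72 h; a higher number here means a weaker inhibitor, a lower number a stronger inhibitor. Within the data shown here, compound 2 gives the higher of the two numbers, and its only neighbour is compound 1, which gives 3760 nM. The step from compound 1 to compound 2 is a 3.2-fold higher number from compound 1 to compound 2 (0.51 log units; beyond the scatter), a change that swapped a pentyl for a bromo on the same aromatic carbon. Compound 3 `CCCCCCCCCCc1cn(C[C@H](O)[C@H]2OC(=O)C(OCc3ccccc3)=C2OCc2ccccc2)nn1` has not yet been tested. It differs from compound 2 in one place: decyl in place of 4-pentylphenyl on an aromatic carbon. Among the measured compounds shown here, no measured step covers the removal of the whole aryl ring in favour of a chain, so the only guide is the modest weakening seen from compound 1 to compound 2. Compound 3 is therefore expected to give a similar or somewhat higher number, an estimated step of a 1.3-fold higher number from compound 2 to compound 3 (0.12 log units; within the scatter), with the estimate for compound 3 in this assay being 16000 nM and a range from 5000 nM to 50000 nM.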

Compound 3, half-maximal inhibitory concentration: 45200 nM
Estimate against measurement, compound 3: 2.8-fold (0.45 log units) below; the measured number falls inside the stated range.
By their numbers in this assay, from the lowest: compound 1; then compound 2; then compound 3.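

In this assay the earlier step changed only the group carried on the six-membered aromatic ring, whereas here the ring itself leaves: decyl replaces 4-pentylphenyl, giving a 3.7-fold higher number from compound 2 to compound 3 (0.57 log units; beyond the scatter). Set against the 4-bromophenyl group, the same chain gives a 12-fold higher number from compound 1 to compound 3 (1.08 log units; beyond the scatter), so among these three compounds both groups that keep the aromatic ring give lower numbers than the open chain. No measurement here explains this difference.

The compounds shown leave open how a shorter chain such as hexyl, a saturated cyclohexyl ring or an unsubstituted phenyl group would behave on this aromatic carbon. Also open, going by these compounds, is whether an amine at the end of the decyl chain would change the number.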